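Swapping a Pyridyl for a Phenyl at the Piperazine Nitrogen

The source may report more compounds than this note shows. Statements on the series, on what has been measured and on what is new or still open speak of the compounds shown alone.

Measured compounds:
compound 1, `Nc1ccccc1NC(=O)c1ccc(CSC(=S)N2CCN(c3ccccc3)CC2)cc1`, 87.4%
compound 2, `CN1CCN(C(=S)SCc2ccc(C(=O)Nc3ccccc3N)cc2)CC1`, 84.4%
compound 3, `Nc1ccccc1NC(=O)c1ccc(CSC(=S)N2CCN(Cc3cccnc3)CC2)cc1`, 64.6%

All three were tested in a functional assay on MGC-803 cells (Homo sapiens) for antiproliferative activity, read by CCK-8 assay, with a stated time of 72 h, tested at 8 uM; a lower number here means a weaker effect, a higher number a stronger effect of the compound at the concentration tested. Compound 3 gives the lowest of the three numbers: in this assay compound 3 gives 64.6%, while compound 1 and compound 2 sit within the scatter of one another, with a number 3 percentage points lower from compound 1 to compound 2 (within the scatter).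

Compound 4, `Nc1ccccc1NC(=O)c1ccc(CSC(=S)N2CCN(Cc3ccccc3)CC2)cc1`, has not yet been measured. It differs from compound 3 in one place: phenyl in place of pyridin-3-yl on a saturated chain carbon bound to an amine nitrogen in a ring.

Among the compounds with values here, two measured steps bear on this change. Adding pyridin-3-yl to the saturated carbon of compound 2 gave a number 19.8 percentage points lower from compound 2 to compound 3 (beyond the scatter), and replacing the phenyl of compound 1 with (pyridin-3-yl)methyl gave a number 22.8 percentage points lower from compound 1 to compound 3 (beyond the scatter). Both steps that introduce the pyridin-3-yl ring lower the number, and the compounds without that ring, compound 1 and compound 2, stand higher. Removing the ring nitrogen to give a benzyl group is therefore expected to raise the number by a modest step, a number 13.4 percentage points higher from compound 3 to compound 4 (beyond the scatter), though a step within the scatter cannot be excluded on three compounds alone.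

For compound 4 the estimate in this assay is 78%, with a range from 62% to 92%.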

Compound 4, a percentage reported as inhibition, at one concentration (the size of the read-out at that concentration, not a potency): 19.7%
Compound 4: the middle estimate sits 58.3 percentage points above what was measured; measured number outside the range, below it.
By their numbers in this assay, from the lowest: compound 4; then compound 3; then compounds 2 and 1 (each within the scatter of the next).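

At this position, a single ring atom decides much of the outcome. In this assay, pyridin-3-yl and phenyl have the same count of heavy atoms and differ only in the ring nitrogen and its one hydrogen-bond acceptor, yet the change gives a number 44.9 percentage points lower from compound 3 to compound 4 (beyond the scatter), a large step from so small an edit. The earlier compounds could suggest that the pyridin-3-yl ring was what held the number down, but among these four the benzyl compound stands lowest, with a number 64.7 percentage points lower from compound 2 to compound 4 (beyond the scatter) and a number 67.7 percentage points lower from compound 1 to compound 4 (beyond the scatter), so the ring nitrogen goes with a higher number when compound 3 and compound 4 are set side by side, and a ring on this saturated chain carbon is not tolerated equally in every form.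

Nothing measured here gives a reason for this large fall. Still open, as far as these compounds go, is whether a (pyridin-4-yl)methyl or (pyridin-2-yl)methyl group would keep the number of compound 3, whether a longer chain such as 2-phenylethyl would behave like benzyl, and how these single-concentration read-outs relate to potency.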